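The source may report more compounds than this note shows. Statements on the series, on what has been measured and on what is new or still open speak of the compounds shown alone.

In a functional assay on DLD-1 cells (Homo sapiens) for antiproliferative activity, read by CellTiter-Glo, with a stated time of 72 h (a lower number here means a stronger inhibitor, a higher number a weaker inhibitor), compound 1 `CC1CCN(C2CCN(S(=O)(=O)c3cn(C)cn3)CC2)CC1` gives > 5000 nM, which is a limit of the assay and not a number. Among the compounds with values here, compound 2 `CC1CCN(C2CCN(S(=O)(=O)c3cccc(Br)c3)CC2)CC1` gives 3.2 nM, the only actual number so far.

Compound 3 `CC1CCN(C2CCN(S(=O)(=O)c3cc(Cl)cc(Cl)c3)CC2)CC1` differs from compound 2 on the sulfonyl sulfur: 3,5-dichlorophenyl in place of 3-bromophenyl on a sulfonyl sulfur. In words, 3,5-dichlorophenyl stands in place of 3-bromophenyl, and the rest of the structure is unchanged.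

Within the data shown here, only one measured step bears on this change: an at least 1500-fold lower number from compound 1 to compound 2 (3.19 log units; beyond the scatter). That step is large and beyond the scatter, and it is the exchange of 1-methyl-1H-imidazol-4-yl for 3-bromophenyl at the same place. The exchange now in question is a narrower one, as both groups are a six-membered aromatic ring of carbon only. A step of the size of an at least 1500-fold lower number from compound 1 to compound 2 (3.19 log units; beyond the scatter) is therefore not expected in this assay. With a single number to go on, the direction remains uncertain, and a slightly higher number is the cautious expectation.

The estimated step is a 1.6-fold higher number from compound 2 to compound 3 (0.19 log units; within the scatter), small and expected to stay near the scatter. For compound 3 the expected value is 5 nM, with an estimated range of 1.5 nM to 20 nM.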

Compound 3, half-maximal inhibitory concentration: 3400 nM
Beside the measured number, compound 3's estimate is 680-fold (2.83 log units) below it, outside the stated range (above it).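

Keeping a six-membered aromatic ring of carbon only on the sulfonyl sulfur does not preserve the activity: with 3,5-dichlorophenyl in place of 3-bromophenyl, this assay shows a 1100-fold higher number from compound 2 to compound 3 (3.03 log units; beyond the scatter), so the two groups are not interchangeable at this place, and the ring type alone does not account for the low number of compound 2. Exchanging 1-methyl-1H-imidazol-4-yl for 3,5-dichlorophenyl gives only an at least 1.4-fold lower number from compound 1 to compound 3 (0.16 log units; that floor lies within the scatter), so this comparison shows no separation beyond the scatter. The value of compound 1 is a limit and not a number: the limit of > 5000 nM in this assay, at which 1 of the 3 values shown sits.

The change from 3-bromophenyl to 3,5-dichlorophenyl alters both the halogen and the pattern on the ring, and the compounds shown cannot separate the two. As far as these compounds go, it remains open whether 3-chlorophenyl would stay close to compound 2, whether 3,5-dibromophenyl would stay close to compound 3, and how a non-halogen group such as 3-methoxyphenyl or 3-cyanophenyl would behave at this place.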